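The source may report more compounds than this note shows. Statements on the series, on what has been measured and on what is new or still open speak of the compounds shown alone.

Of the compounds shown here, two sharing one core have been read in a physicochemical assay for lipophilicity; on this read-out higher numbers stand for higher lipophilicity and lower numbers for lower lipophilicity. For the measured compounds named here, there, compound 1 (`CCn1cnc2c(-c3ccc(F)c(-c4ccc(S(=O)(=O)C(C)C)cc4OC)c3)cnnc21`) gives 3 and compound 2 (`CCn1cnc2c(-c3ccc(F)c(-c4ccc(S(=O)(=O)C5CC5)cc4OC)c3)cnnc21`) gives 2.7, so compound 2 stands within the scatter of its only measured neighbour. Compound 3 (`CCn1cnc2c(-c3ccc(F)c(-c4ccc(S(=O)(=O)C5COC5)cc4OC)c3)cnnc21`) carries oxetan-3-yl in place of cyclopropyl on a sulfonyl sulfur. Going by the values given here, only one measured step bears on this place, namely a number 0.30 log units lower from compound 1 to compound 2 (within the scatter), with cyclopropyl in place of isopropyl on the same sulfonyl sulfur. That step brings in no hetero atom, so it sets no size for the new change, and the expectation rests on the structural change alone. In this assay, a move to a lower number, beyond the scatter, is expected, and the expected move is a number 0.70 log units lower from compound 2 to compound 3 (beyond the scatter). For compound 3 the estimate is 2, within an expected range from 1.6 to 2.4.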

Compound 3, distribution coefficient: 2.2
For compound 3 the middle estimate is 0.20 log units below the measured one; low and high end bracket the measured number.
By their numbers in this assay, from the lowest: compound 3; then compounds 2 and 1 (each within the scatter of the next).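

On this sulfonyl sulfur, exchanging a carbon-only ring for one with a hetero atom moves the number in this assay beyond the scatter, with a number 0.50 log units lower from compound 2 to compound 3 (beyond the scatter), whereas the earlier cyclopropyl-for-isopropyl step stayed within it. The same holds against the isopropyl group, with a number 0.80 log units lower from compound 1 to compound 3 (beyond the scatter), so compound 3 stands apart from both earlier compounds, which lie within the scatter of each other. Nothing available explains the size of these steps.

The compounds shown leave open whether the shift belongs to the oxygen itself or to the four-membered ring, which a cyclobutyl group on the same sulfur would separate. They also leave open how an azetidin-3-yl ring, with nitrogen in place of that oxygen, would read here.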